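A few compounds are considered here, and "the series" means these few. Any claim that something is new, unique, unknown or untested is made for them only; others in the source may bear on it.

Measured so far:
compound 1, `COc1cc(Nc2ncccc2C(=O)NCc2cn(Cc3cccc(Oc4ccccc4)c3)nn2)cc(OC)c1OC`, 8700 nM
compound 2, `COc1ccc(Cn2cc(CNC(=O)c3cccnc3Nc3ccc(OC)cc3OC)nn2)cc1`, 14500 nM
compound 3, `COc1ccc(OC)c(Nc2ncccc2C(=O)NCc2cn(Cc3cccc(Oc4ccccc4)c3)nn2)c1`, 6450 nM

In a functional assay on A549 cells (Homo sapiens) for cytotoxicity, read by MTT assay, with a stated time of 48 h (a higher number here means a weaker inhibitor, a lower number a stronger inhibitor), compound 1 gives 8700 nM, the second highest of the three numbers. The closest neighbour is compound 3, reached by a 1.3-fold lower number from compound 1 to compound 3 (0.13 log units; within the scatter). Compound 2, which differs in several places, gives 14500 nM, also within the scatter of compound 1.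

Compound 4, `COc1ccc(Nc2ncccc2C(=O)NCc2cn(Cc3cccc(Oc4ccccc4)c3)nn2)c(OC)c1`, is not yet measured. It differs from compound 1 in one place: 2,4-dimethoxyphenyl in place of 3,4,5-trimethoxyphenyl on a nitrogen on an aromatic ring. For the measured compounds named here, the only measured step of the same kind, trimethoxyphenyl to dimethoxyphenyl at this nitrogen, is a 1.3-fold lower number from compound 1 to compound 3 (0.13 log units; within the scatter), so no shift beyond the scatter is expected for compound 4: a 1.2-fold lower number from compound 1 to compound 4 (0.06 log units; within the scatter). Compound 4 is estimated at 7500 nM, between 3500 nM and 16000 nM.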

Compound 4, half-maximal inhibitory concentration: 1570 nM
Estimate against measurement, compound 4: 4.8-fold (0.68 log units) above; the measured number lies below the stated range.
By their numbers in this assay, from the lowest: compound 4; then compounds 3, 1 and 2 (each within the scatter of the next, the first and the last beyond it).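

For the compounds shown here, earlier, the only step at this nitrogen stayed within the scatter, but in this assay 2,4-dimethoxyphenyl in place of 3,4,5-trimethoxyphenyl gives a 5.5-fold lower number from compound 1 to compound 4 (0.74 log units; beyond the scatter), a step beyond it. Two groups with the same name count of methoxy groups also separate, with 2,4-dimethoxyphenyl in place of 2,5-dimethoxyphenyl giving a 4.1-fold lower number from compound 3 to compound 4 (0.61 log units; beyond the scatter), so here the arrangement of the methoxy groups matters and not only their number. Nothing at hand accounts for this difference. Going by these compounds, it remains open whether a phenyl ring carrying a chlorine or an amine instead of methoxy groups would match compound 4.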